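A few compounds are considered here, and "the series" means these few. Any claim that something is new, unique, unknown or untested is made for them only; others in the source may bear on it.

Two compounds of the series have numbers in a functional assay on MCF7 cells (Homo sapiens) for antiproliferative activity, read by MTT assay, with a stated time of 72 h, tested at 100 uM (a lower number here means a stronger effect, a higher number a weaker effect of the compound at the concentration tested), so far. Compound 1 `COC(C(=O)OC(C)Cn1cnc2c1c(=O)n(C)c(=O)n2C)c1cccc2ccccc12` gives 83.3% in this assay, and compound 2 `CC(Cn1cnc2c1c(=O)n(C)c(=O)n2C)OC(=O)CC(=O)c1ccc(F)cc1` gives 83.8%. The two numbers lie within the scatter of each other, so compound 1 is not set apart from compound 2; both leave most of the cell growth untouched at the concentration tested.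

Compound 3 `COC(C(=O)OC(C)Cn1cnc2c1c(=O)n(C)c(=O)n2C)c1ccc2ccccc2c1` has not yet been measured. It differs from compound 1 only in how the same atoms are joined: naphthalen-2-yl in place of naphthalen-1-yl on a saturated chain carbon bound to a carbonyl carbon and an oxygen on a saturated carbon. Among the measured compounds shown here, no pair of measured compounds shows what such a change does in this assay, so there is no step to read from. The expectation is that naphthalen-2-yl in place of naphthalen-1-yl changes little, and the expected step is a number 1.3 percentage points lower from compound 1 to compound 3 (within the scatter), none beyond the scatter in either direction. Compound 3 is therefore estimated at 82%, with a range from 68% to 95%.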

Compound 3, a percentage reported as activity, at one concentration (the size of the read-out at that concentration, not a potency): 83.7%
For compound 3 the middle estimate is 1.7 percentage points below the measured one, and the stated range covers the measured number.
By their numbers in this assay, from the lowest: compounds 1, 3 and 2 (each within the scatter of the next).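

Naphthalen-2-yl in place of naphthalen-1-yl, on a saturated chain carbon bound to a carbonyl carbon and an oxygen on a saturated carbon, is the first single-place step in the series, and in this assay it reads a number 0.4 percentage points higher from compound 1 to compound 3 (within the scatter). At this place the two ways of joining the same carbon atoms are therefore not told apart at the concentration tested, an observation that the unrelated pair of compound 1 and compound 2 could not provide. Nothing measured here bears on the reason for this result.

Still open, on these data alone, is whether a group other than a naphthyl at this place, such as a phenyl or a pyridine ring, would stand apart from this level. The same applies to an amine or a carboxylic acid on the chain carbon in place of the methoxy group.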